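Trifluoromethyl for methoxy on the indole ring

This account rests on a few compounds, and the source may have more. Where it says the series, first, only, none or still open, it means among the compounds named here.

Compound 1 `COC(=O)[C@@]1(C)CCC=C2[C@@H]1CC[C@@H](C)[C@]2(C)Cc1c(C)[nH]c2ccc(Br)cc12`: 15000 nM
Compound 2 `COC(=O)[C@@]1(C)CCC=C2[C@@H]1CC[C@@H](C)[C@]2(C)Cc1c(C)[nH]c2ccc(Cl)cc12`: 18000 nM
Compound 3 `COC(=O)[C@@]1(C)CCC=C2[C@@H]1CC[C@@H](C)[C@]2(C)Cc1c(C)[nH]c2ccc(OC)cc12`: 17000 nM

Three compounds share one core and differ only in the group on an aromatic carbon of the fused ring. In a functional assay on WiDr cells (Homo sapiens) for inhibition, read by sulforhodamine B assay, with a stated time of 48 h (on this read-out higher numbers stand for weaker inhibition of growth and lower numbers for stronger inhibition of growth), compound 1 gives 15000 nM, compound 2 gives 18000 nM and compound 3 gives 17000 nM. The three numbers sit close together: a 1.2-fold higher number from compound 1 to compound 2 (0.08 log units; within the scatter), a 1.1-fold higher number from compound 1 to compound 3 (0.05 log units; within the scatter) and a 1.1-fold lower number from compound 2 to compound 3 (0.02 log units; within the scatter). Compound 3 thus stands within the scatter of both others, nearest to compound 2 and furthest from compound 1, and nothing separates the three in this assay.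

Compound 4 `COC(=O)[C@@]1(C)CCC=C2[C@@H]1CC[C@@H](C)[C@]2(C)Cc1c(C)[nH]c2ccc(C(F)(F)F)cc12` carries the change (trifluoromethyl in place of methoxy on an aromatic carbon). For the measured compounds named here, no measured step involves a trifluoromethyl group, so the bearing of the earlier steps is indirect: every swap at this position so far, bromo to chloro, bromo to methoxy and chloro to methoxy, stayed within the scatter. On that basis a further swap at the same position is expected to give no step beyond the scatter, in either direction, so that no change at the digits printed from compound 3 to compound 4 (within the scatter) is the expected outcome. Compound 4 is therefore estimated at 17000 nM in this assay, with a range from 7000 nM to 40000 nM.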

Compound 4, concentration for 50% growth inhibition: 21000 nM
Estimate against measurement, compound 4: 1.2-fold (0.09 log units) below, and the stated range covers the measured number.
By their numbers in this assay, from the lowest: compounds 1, 3, 2 and 4 (each within the scatter of the next).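

In this assay the trifluoromethyl group joins bromo, chloro and methoxy at this aromatic carbon without separating from any of them: the steps are a 1.2-fold higher number from compound 3 to compound 4 (0.09 log units; within the scatter) and a 1.2-fold higher number from compound 2 to compound 4 (0.07 log units; within the scatter) and a 1.4-fold higher number from compound 1 to compound 4 (0.15 log units; within the scatter) and all three stay within the scatter. The earlier compounds had shown this flatness only for halogens and methoxy, whereas this change replaces methoxy with a group that has more heavy atoms and no hydrogen-bond acceptor, and neither difference comes with a step beyond the scatter. The four compounds therefore give no ranking of these groups at this position, and no measurement offered here explains why the read-out stays so flat.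

From the compounds shown here alone, it remains open whether a group of another kind at this aromatic carbon, such as an amine, a carboxylic acid or a longer chain, would give a step beyond the scatter. The compounds shown also leave open whether a change elsewhere on the shared core would move the number, since all four differ only at this one place.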